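Three compounds at the limit, a fourth to come

The source may hold more compounds than are shown below. What is called first, only, known or untested is meant among the compounds shown, and "the series" means these compounds.

Compound 1, `COc1ccc(C2=C(c3cc(OC)c(OC)c(OC)c3)CC(O[SiH2]C(C)(C)C)C2=O)cc1[N+](=O)[O-]`, gives > 100 ug/mL, which is a limit of the assay rather than a number.
Compound 2, `COc1ccc(C2=C(c3cc(OC)c(OC)c(OC)c3)C(=O)C(O)C2)cc1NC(=O)c1ccccc1`, gives > 100 ug/mL, again a limit of the assay.
Compound 3, `O/N=C1/CC(O)C(c2ccccc2)=C1c1ccccc1`, gives > 100 ug/mL, also a limit of the assay.

In an ADME assay on HEK293 cells (Homo sapiens) for cytotoxicity, read by MTT assay, with a stated time of 72 h (a lower number here means a stronger inhibitor, a higher number a weaker inhibitor), compound 2 stands where every measured compound stands: at the limit of > 100 ug/mL in this assay, at which 3 of the 3 values shown sit. No measured number is available for compound 2, only this limit, and the same holds for the two other measured compounds, so nothing separates them.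

The unmeasured compound 4, `COc1ccc(C2=C(c3cc(OC)c(OC)c(OC)c3)C(=O)C(O)C2)cc1OC(C)C`, is compound 2 with one change, (isopropoxy in place of benzamido on an aromatic carbon). Among the measured compounds shown here, no pair of measured compounds differs in a single place, so no measured step shows how such a change acts in this assay. For the measured compounds named here, with the three shared limits as the only guide, the expected step in this assay is none beyond the usual scatter, and a fourth limit rather than a number is the most likely outcome.

Compound 4 is therefore estimated to give 100 ug/mL, with a range from 40 ug/mL to 250 ug/mL. The step this estimate implies is expected to be a number no higher from compound 2 to compound 4 (the limit leaves the size open).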

Compound 4, half-maximal inhibitory concentration: > 100 ug/mL
Compound 4 was reported as a limit; the forecaster's own chance of this, stated with the estimate: 80%; the middle value lies on the limit itself.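

Compound 2 and compound 4 are each reported only as a limit in this assay, so the step from benzamido to isopropoxy cannot be read. The compounds shown leave open which structure, if any, would give an actual number rather than a limit, since all of them sit at the same point: the limit of > 100 ug/mL in this assay, at which 4 of the 4 values shown sit.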